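A few compounds are considered here, and "the series" means these few. Any claim that something is new, unique, unknown or untested is made for them only; others in the source may bear on it.

Values in a physicochemical assay for lipophilicity, at pH 7.4; on this read-out higher numbers stand for higher lipophilicity and lower numbers for lower lipophilicity:
- Compound 1 `Cc1cc(C(N)=O)nn1Cc1cc(Cl)ccc1OCC(C)C`: 3.1
- Compound 2 `Cc1cc(C(=O)NN2CCOCC2)nn1Cc1cc(Cl)ccc1OCC(C)C`: 3.1
- Compound 3 `Cc1cc(NC(=O)OC(C)(C)C)nn1Cc1cc(Cl)ccc1OCC(C)C`: > 3.7, a limit and not a number

Compound 3 stands at the limit of > 3.7 in this assay, at which 1 of the 3 values shown sits. Its true position on this scale is therefore open, and any step starting from it carries that uncertainty.

The next compound is compound 4 `Cc1cc(NC(=O)OC2CCOCC2)nn1Cc1cc(Cl)ccc1OCC(C)C`, which has not yet been measured. The structural change is oxan-4-yl in place of tert-butyl on an oxygen next to a carbonyl group. Put another way, tert-butoxycarbonyl gives way to ((oxan-4-yl)oxy)carbonyl, while the rest of compound 3 is kept.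

Within the data shown here, no measured step makes this exact exchange. Two steps bring in the whole (tert-butoxycarbonyl)amino group, and they show a number at least 0.60 log units higher from compound 1 to compound 3 (beyond the scatter) and a number at least 0.60 log units higher from compound 2 to compound 3 (beyond the scatter). These steps bear on the size of the change only loosely. The step that brings in morpholin-4-yl shows no change at the digits printed from compound 1 to compound 2 (within the scatter), which argues against expecting a very large fall from a ring alone.

With one hydrogen-bond acceptor entering and the tert-butyl leaving, a lower number is expected in this assay, estimated as a number at least 0.20 log units lower from compound 3 to compound 4 (that floor lies within the scatter). For compound 4 the expected value is 3.5, with an estimated range of 3 to 4.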

Compound 4, distribution coefficient: 3.4
For compound 4 the middle estimate is 0.10 log units above the measured one; low and high end bracket the measured number.
By their numbers in this assay, from the lowest: compounds 1, 2 and 4 (each within the scatter of the next). At a limit, above all of these: compound 3.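

In this assay, oxan-4-yl in place of tert-butyl on an oxygen next to a carbonyl group gives a number at least 0.30 log units lower from compound 3 to compound 4 (that floor lies within the scatter). Compound 3 carries > 3.7, which is a limit and not a number, while compound 4 gives a number that can be read on the scale, so this group on this oxygen brings the series back into the measurable range of this assay. Compound 1 gives 3.1 and compound 4 gives 3.4, values within the scatter of each other, so with oxan-4-yl in the tert-butyl place this side of the core no longer stands apart from the carbamoyl of compound 1, as compound 3 does.

The full size of the exchange stays unread because one end of the step is not a number: the limit of > 3.7 in this assay, at which 1 of the 4 values shown sits. Still open is how the same oxygen behaves with a group such as a piperidin-4-yl ring carrying a basic amine, a methoxyethyl chain or a carboxylic acid, and whether the oxan-4-yl exchange gives a similar step on another core, since this single pair is the only case shown.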